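Compound 4: A Carbon Ring Replaces the Nitrogen Ring

The source may hold more compounds than are shown below. What is called first, only, known or untested is meant among the compounds shown, and "the series" means these compounds.

- compound 1 `C=C1CCC2[C@](C)(CO)[C@H](O)CC[C@@]2(C)[C@@H]1CCn1ccc(=O)[nH]c1=O`: > 100000 nM
- compound 2 `C=C1CCC2C(C)(CO)[C@H](O)CC[C@@]2(C)[C@@H]1CCn1c(N)nccc1=O`: > 100000 nM
- compound 3 `C=C1CCC2[C@](C)(CO)[C@H](O)CC[C@@]2(C)[C@@H]1CCn1cnc2c(N)ncnc21`: > 100000 nM

In a functional assay on RAW264.7 cells (Mus musculus) for inhibition, read by Griess assay, with stated times of 3 h and 24 h (on this read-out lower numbers stand for stronger inhibition and higher numbers for weaker inhibition), compound 1 gives > 100000 nM, which is a limit of the assay and not a number. The same holds for the other two measured compounds: the limit of > 100000 nM in this assay, at which 3 of the 3 values shown sit. Going by the values given here, no measured step therefore shows how large a change to expect.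

Compound 4 `C=C1CCC2[C@](C)(CO)[C@H](O)CC[C@@]2(C)[C@@H]1CCOc1ccccc1O` keeps the core of compound 1 and changes one group: a group of 8 heavy atoms (6 carbon, 2 oxygen; one six-membered aromatic ring of carbon only) in place of a group of 8 heavy atoms (4 carbon, 2 nitrogen, 2 oxygen; one six-membered aromatic ring with 2 hetero atoms), on a saturated chain carbon, two bonds along the chain from a saturated ring carbon. The expected step of an at least 2.5-fold lower number from compound 1 to compound 4 (0.39 log units; beyond the scatter) is a rough estimate toward stronger inhibition, and compound 4 may also stay at the limit. For compound 4 the estimated value is 40000 nM, with an expected range from 10000 nM to 150000 nM.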

Compound 4, half-maximal inhibitory concentration: 47700 nM
The estimate for compound 4 lay 1.2-fold (0.08 log units) below the measured number; low and high end bracket the measured number.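

In this assay, going by these compounds alone, the 2-hydroxyphenoxy group, on a saturated chain carbon, gives an at least 2.0-fold lower number from compound 1 to compound 4 (0.32 log units; beyond the scatter) and so provides the first step that can be read at this position. For compound 1 the value > 100000 nM is a limit and not a number, so the true step may be larger. Compound 4 is the only compound shown that has left that limit: the limit of > 100000 nM in this assay, at which 3 of the 4 values shown sit.

The compounds shown do not separate the effect of the ring's hydroxyl group from that of the oxygen linking the ring to the chain. A plain phenoxy group or a 2-aminophenoxy group in the same place would begin to separate them.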